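The compounds below may be only part of what the source reports. "The series", "measured", "known", "first", "only" and "open" are said of these compounds alone.

Three compounds have been measured in a functional assay on HL-60 cells (Homo sapiens) for antiproliferative activity, with a stated time of 24 h; a lower number here means a stronger inhibitor, a higher number a weaker inhibitor:

compound 1, `NC(=O)c1c(NC(=O)c2ccccc2Cl)sc2c1CCN(C(=S)Nc1ccccc1)C2`, giving 5940 nM
compound 2, `NC(=O)c1c(NC(=O)c2ccccc2Cl)sc2c1CCN(C(=S)Nc1ccccc1F)C2`, giving 4970 nM
compound 3, `NC(=O)c1c(NC(=O)c2ccccc2)sc2c1CCN(C(=S)Nc1ccccc1Cl)C2`, giving 13800 nM

Compound 3 has the highest number of the three, and its gaps to compound 1 and to compound 2 both lie beyond the usual scatter. Compound 3 and compound 1 share the same atoms joined differently, and the difference between the two cores is not broken down here.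

Compound 1 and compound 2 differ in one place: fluoro in place of hydrogen on an aromatic carbon. This gave a 1.2-fold lower number from compound 1 to compound 2 (0.08 log units; within the scatter).

Compound 4, `NC(=O)c1c(NC(=O)c2ccccc2F)sc2c1CCN(C(=S)Nc1ccccc1Cl)C2`, is not yet measured. It differs from compound 3 in the same way: fluoro in place of hydrogen on an aromatic carbon. Here the fluoro enters on the benzamido side rather than on the anilino side, but the place is described in the same words, so this is the same kind of change.

Going by the values given here, since the only measured example of this change gave a 1.2-fold lower number from compound 1 to compound 2 (0.08 log units; within the scatter), a step within the scatter, the step of a 1.2-fold lower number from compound 3 to compound 4 (0.06 log units; within the scatter) is expected to be similarly small. Compound 4 is therefore estimated at 12000 nM, most likely between 6000 nM and 25000 nM.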

Compound 4, half-maximal inhibitory concentration: 12500 nM
The estimate for compound 4 lay 1.0-fold (0.02 log units) below the measured number, and the stated range covers the measured number.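

In this assay, fluoro in place of hydrogen on an aromatic carbon gave a 1.1-fold lower number from compound 3 to compound 4 (0.04 log units; within the scatter), a step too small to tell apart from the usual spread of repeated measurements. Set beside the earlier example, the two steps agree across two cores: the same change on two cores in this assay, a 1.2-fold lower number (0.08 log units; within the scatter) from compound 1 to compound 2 and a 1.1-fold lower number (0.04 log units; within the scatter) from compound 3 to compound 4, 1.1-fold (0.03 log units) apart, within the scatter of two such steps. This shows that, in these two cases, the change carried from one core to the other without a step beyond the scatter, even though the fluoro enters the anilino side in compound 2 and the benzamido side in compound 4; it does not show that fluoro would behave this way on other cores or in other places, and a small real effect could stay hidden within the scatter.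

The compounds shown leave open whether a methoxy group, a trifluoromethyl group or an amine in place of the same hydrogen would give a step beyond the scatter. As far as these compounds go, it also remains open whether the fluoro step would stay this small on a core carrying a carboxylic acid in place of the amide.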